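This account rests on a few compounds, and the source may have more. Where it says the series, first, only, none or still open, it means among the compounds named here.

Compound 3 `CS(=O)(=O)Nc1ccc2c(c1)S(=O)(=O)N=C(C1=C(O)[C@H]3CCC[C@H]3N(Cc3cccc(C(F)(F)F)c3)C1=O)N2` is the point of departure. In an ADME assay on Huh-7 cells (Homo sapiens) for cytotoxicity, with a stated time of 72 h (on this read-out higher numbers stand for lower toxicity in this test and lower numbers for higher toxicity in this test), compound 3 gives > 33000 nM, which is a limit of the assay and not a number. Two close relatives share its core. Compound 1 `CS(=O)(=O)Nc1ccc2c(c1)S(=O)(=O)N=C(C1=C(O)[C@H]3CCC[C@H]3N(Cc3ccc(F)c(F)c3)C1=O)N2` gives > 1000 nM in this assay, again a limit rather than a number. Compound 2 `CS(=O)(=O)Nc1ccc2c(c1)S(=O)(=O)N=C(C1=C(O)[C@H]3CCC[C@H]3N(Cc3ccc(F)c(Cl)c3)C1=O)N2` gives > 1000 nM in this assay, also a limit. The steps between these three are therefore not readable in size: a step that the two limits leave unreadable from compound 1 to compound 2, a step that the two limits leave unreadable from compound 1 to compound 3 and a step that the two limits leave unreadable from compound 2 to compound 3.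

Compound 4 `Cc1cc(CN2C(=O)C(C3=NS(=O)(=O)c4cc(NS(C)(=O)=O)ccc4N3)=C(O)[C@H]3CCC[C@H]32)ccc1F` differs from compound 3 by 4-fluoro-3-methylphenyl in place of 3-(trifluoromethyl)phenyl on a saturated chain carbon bound to an amide-type nitrogen in a ring. The measured steps that bear on this kind of change are the two that also exchange the group on that carbon, from compound 1 to compound 3 and from compound 2 to compound 3, and neither has a readable size. What the numbers do show is that every value sits at a limit: the limit of > 1000 nM in this assay, at which 2 of the 3 values shown sit, and (the limit of > 33000 nM in this assay, at which 1 of the 3 values shown sits). In this assay no step beyond the scatter is expected for compound 4, and a further limit is the likely outcome. Compound 4 is estimated at 40000 nM, with a range from 10000 nM to 120000 nM. The expected step is a step that the limit leaves unreadable from compound 3 to compound 4.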

Compound 4, half-maximal cytotoxic concentration: > 1000 nM
Compound 4 ended at the assay's limit; the forecaster's own chance of this, stated with the estimate: 80%; the middle value lies beyond the limit too.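

No step from compound 1, compound 2 or compound 3 to compound 4 can be read in size, since all four values are limits and not numbers: the limit of > 1000 nM in this assay, at which 3 of the 4 values shown sit.

The compounds shown leave open how the benzyl group on the shared core affects the real half-maximal cytotoxic concentration in this assay.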